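Dropping the ring: from compound 2 to a plain hexyl chain

This account rests on a few compounds, and the source may have more. Where it says the series, first, only, none or still open, it means among the compounds named here.

Of the compounds shown here, two of a shared core have numbers so far. Compound 1 `O=C(O)Cn1c(SCCCCOc2ccccc2)nc2ccccc21` gives 1400 nM in an assay on HEK293 cells for displacement of a labelled ligand from prostaglandin D2 receptor 2 (Homo sapiens); on this read-out lower numbers stand for stronger inhibition and higher numbers for weaker inhibition. Compound 2 `O=C(O)Cn1c(SCCc2ccccc2)nc2ccccc21` gives 881 nM in this assay, the lowest of the two numbers, and compound 1 sits within the usual scatter of it, so the pair shows no difference of rank.

Compound 3 `CCCCCCSc1nc2ccccc2n1CC(=O)O` has not been measured in this assay. It differs from compound 2 by one change: butyl in place of phenyl on a saturated chain carbon, two bonds along the chain from a sulfur, which, cut one bond further out, reads benzyl to pentyl. Among the measured compounds shown here, nothing among the measured compounds shows what removing an aromatic ring from this chain does, so no step of the same kind can be pointed to. He expects a modest move to a higher number, about a 1.8-fold higher number from compound 2 to compound 3 (0.26 log units; within the scatter), but a step that stays within the scatter cannot be ruled out. For compound 3 the expected value in this assay is 1600 nM, with a range from 500 nM to 5000 nM.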

Compound 3, half-maximal inhibitory concentration: 1360 nM
The estimate for compound 3 lay 1.2-fold (0.07 log units) above the measured number; measured number inside the range.
By their numbers in this assay, from the lowest: compounds 2, 3 and 1 (each within the scatter of the next).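

In this assay, butyl in place of phenyl on a saturated chain carbon, two bonds along the chain from a sulfur, gives a 1.5-fold higher number from compound 2 to compound 3 (0.19 log units; within the scatter) and so stays within the scatter: at this position, the aromatic ring is not needed for a number in this range. Ethyl in place of phenoxy, four bonds along the chain from a sulfur, agrees, giving a 1.0-fold lower number from compound 1 to compound 3 (0.01 log units; within the scatter) and leaving the plain hexyl chain level with both ring-bearing chains. Nothing measured here explains why the ring can be lost without a step beyond the scatter.

As far as these compounds go, no change at this position has yet moved the number beyond the scatter, so how much the chain matters remains open. Whether a longer chain, or an amine or a carboxylic acid at its far end, would separate from these three is also unknown.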